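Methoxy at the para position of the cinnamamide

The source may report more compounds than this note shows. Statements on the series, on what has been measured and on what is new or still open speak of the compounds shown alone.

Three compounds share one core and were measured in an ADME assay on Vero cells (Chlorocebus sabaeus) for cytotoxicity, read by MTT assay, with a stated time of 72 h; a higher number here means that more compound is tolerated, a lower number that less compound is tolerated. Compound 1 `Nc1ccc(/C=C/C(=O)Nc2nnc(-c3ccccc3)[nH]2)cc1` gives 1910000 nM. Compound 2 `O=C(/C=C/c1ccc(Cl)cc1)Nc1nnc(-c2ccccc2)[nH]1` gives 1620000 nM. Compound 3 `O=C(/C=C/c1ccccc1)Nc1nnc(-c2ccccc2)[nH]1` gives 1570000 nM. All three stand together: the step of a 1.2-fold lower number from compound 1 to compound 3 (0.09 log units; within the scatter) and the step of a 1.0-fold lower number from compound 2 to compound 3 (0.01 log units; within the scatter) are both small, as is a 1.2-fold lower number from compound 1 to compound 2 (0.07 log units; within the scatter), so compound 3 sits within the scatter of both of its neighbours.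

Compound 4 `COc1ccc(/C=C/C(=O)Nc2nnc(-c3ccccc3)[nH]2)cc1` is not yet measured. It differs from compound 3 by methoxy in place of hydrogen on an aromatic carbon. Among the compounds with values here, two measured steps bear on this: substitution at the same aromatic carbon by amino or chloro, seen in the steps from compound 1 and compound 2 to compound 3, changed this assay by amounts well inside the scatter. A methoxy entering at that carbon is therefore expected to move the number by no more than the scatter allows, in no preferred direction. The expected step is a 1.0-fold higher number from compound 3 to compound 4 (0.01 log units; within the scatter). For compound 4 the estimate in this assay is 1600000 nM, with a range from 900000 nM to 2800000 nM.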

Compound 4, half-maximal cytotoxic concentration: 1280000 nM
Beside the measured number, compound 4's estimate is 1.3-fold (0.10 log units) above it; low and high end bracket the measured number.
By their numbers in this assay, from the lowest: compounds 4, 3, 2 and 1 (each within the scatter of the next).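

In this assay, methoxy on an aromatic carbon para to a large group is the third substituent at this carbon to stay within the scatter of the unsubstituted compound (a 1.2-fold lower number from compound 3 to compound 4 (0.09 log units; within the scatter)). It also stays within the scatter of the two substituted compounds (a 1.3-fold lower number from compound 2 to compound 4 (0.10 log units; within the scatter); a 1.5-fold lower number from compound 1 to compound 4 (0.17 log units; within the scatter)), and the last of these is the largest step seen so far at this carbon. Hydrogen, amino, chloro and methoxy are thus not separated here, and nothing shown offers a reason for that.

From the compounds shown here alone, whether this holds for a carboxylic acid, a dimethylamino group or a longer alkoxy chain at the same carbon remains open. So does the outcome of placing methoxy on another carbon of this ring.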